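A few compounds are considered here, and "the series" means these few. Any claim that something is new, unique, unknown or untested is made for them only; others in the source may bear on it.

Values are from a functional assay on HL-60 cells (Homo sapiens) for cytotoxicity, read by WST assay, with a stated time of 48 h; on this read-out lower numbers stand for an effect already at smaller amounts and higher numbers for an effect only at larger amounts of compound.

Compound 1 `COc1ccc(C[C@H]2COC(=O)[C@@H]2Cc2ccc(Cl)c(Cl)c2)cc1O`: 32000 nM
Compound 2 `COc1ccc(C[C@H]2COC(=O)[C@@H]2Cc2ccc(Cl)c(Cl)c2)cc1OC`: 24000 nM
Compound 3 `Oc1ccc(C[C@H]2COC[C@@H]2Cc2ccc(Cl)c(Cl)c2)cc1`: 31000 nM

Compound 1 and compound 2 differ by methyl in place of hydrogen on an oxygen on an aromatic ring; this gives a 1.3-fold lower number from compound 1 to compound 2 (0.12 log units; within the scatter). Compound 3 and compound 1 have different cores; the difference between the two cores is not broken down here, and their two values lie within the scatter of each other. Compound 4 `COc1ccc(C[C@H]2COC[C@@H]2Cc2ccc(Cl)c(Cl)c2)cc1` is not yet measured; it relates to compound 3 as compound 2 does to compound 1, by methyl in place of hydrogen on an oxygen on an aromatic ring, the same change at the same kind of place. In this assay the step of a 1.2-fold lower number from compound 3 to compound 4 (0.09 log units; within the scatter) is expected, on the basis that the earlier matched pair gave a 1.3-fold lower number from compound 1 to compound 2 (0.12 log units; within the scatter), which was within the scatter, and that the cores differ only at a part not broken down here. Compound 4 is therefore estimated at 25000 nM, between 12000 nM and 50000 nM.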

Compound 4, half-maximal effective concentration: 39000 nM
Estimate against measurement, compound 4: 1.6-fold (0.19 log units) below; measured number inside the range.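

In this assay the change from hydroxy to methoxy gives a 1.3-fold higher number from compound 3 to compound 4 (0.10 log units; within the scatter) and so stays within the scatter on this second core as well. Set beside the step on the core of compound 1, the new step does not differ from it: the same change on two cores in this assay, a 1.3-fold lower number (0.12 log units; within the scatter) from compound 1 to compound 2 and a 1.3-fold higher number (0.10 log units; within the scatter) from compound 3 to compound 4, 1.7-fold (0.22 log units) apart, within the scatter of two such steps. On these two cores the change therefore carries over as a step too small to read, but that does not show a shared effect of the change, nor that a larger step would carry over in the same way.

Open, on these data alone, is whether another group in place of the hydroxy, such as an amine, a carboxylic acid or a longer chain on the oxygen, would move the number beyond the scatter. Also open, as far as these compounds go, is how the change behaves on any third core.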